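This account rests on a few compounds, and the source may have more. Where it says the series, first, only, none or still open, it means among the compounds named here.

Measured so far, in a physicochemical assay for acid dissociation:
Compound 1 `COc1ccc(F)cc1CNCCCNc1ccnc2cc(Cc3ccccc3)ccc12` gives 9.47.
Compound 2 `COc1ccc(F)cc1CNCCCNc1ccnc2cc(Cc3cccc(C(F)(F)F)c3)ccc12` gives 9.47.

Compound 2 stands level with compound 1 at the digits shown, and the step between them, no change at the digits printed from compound 1 to compound 2 (within the scatter), lies within the scatter of this assay. Compound 3 `COc1ccc(F)cc1CNCCCNc1ccnc2cc(-c3ccc(C(C)(C)C)cc3)ccc12` is not yet measured. Its structure departs from compound 2 in one place: 4-(tert-butyl)phenyl in place of 3-(trifluoromethyl)benzyl on an aromatic carbon. Going by the values given here, only one measured step bears on this change. It altered a group on the same aromatic ring of the shared core, and it left this assay unchanged, as no change at the digits printed from compound 1 to compound 2 (within the scatter) shows. The new group again sits on that ring, far from the part of the shared core that the two measured values have in common. The expected step in this assay is therefore none beyond the scatter, which is what no change at the digits printed from compound 2 to compound 3 (within the scatter) expresses. Compound 3 is estimated at 9.47, within a range from 9.1 to 9.8.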

Compound 3, acid dissociation constant: 9.47
Beside the measured number, compound 3's estimate shows no gap at the digits printed, and the stated range covers the measured number.
By their numbers in this assay, from the lowest: compounds 1, 2 and 3 (each within the scatter of the next).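

In this assay, the earlier pair differed only by a trifluoromethyl on the benzyl group, whereas this result replaces that whole group at the same aromatic carbon: 4-(tert-butyl)phenyl takes the place of 3-(trifluoromethyl)benzyl (no change at the digits printed from compound 2 to compound 3 (within the scatter)). The comparison with the plain benzyl group reads the same (no change at the digits printed from compound 1 to compound 3 (within the scatter)), so all three groups at this position stay within the scatter of one another. No measurement shown gives a reason for this result.

The compounds shown leave open whether a group at this aromatic carbon that carries an amine or a carboxylic acid would also stay within the scatter. They also leave open what a change elsewhere on the shared core, such as a longer chain, would do to this number.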